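Cyclopropyl to methyl on the amide nitrogen, second core

The compounds below may be only part of what the source reports. "The series", "measured", "known", "first", "only" and "open" are said of these compounds alone.

For the measured compounds named here, compound 1 `O=C(/C=C1\CCc2cc(F)cc(F)c21)NC1CC1` gives 100% in a functional assay on the whole organism with Mus musculus as the target, at a dose of 100 mg/kg by the intraperitoneal route (on this read-out lower numbers stand for less inhibition and higher numbers for more inhibition at the one dose given (going by the name of the read-out)), the highest of the three numbers so far. Compound 3 `O=C(/C=C1\CCc2ccc(Cl)cc21)NC1CC1` gives 50% in this assay, and compound 2 `CNC(=O)/C=C1\CCc2ccc(Cl)cc21` gives 16%. The difference between the core of compound 1 and the core of compound 3 is not broken down here. From compound 3 to compound 2 the change is methyl in place of cyclopropyl on an amide-type nitrogen; it produced a number 34 percentage points lower from compound 3 to compound 2 (beyond the scatter). Compound 4 `CNC(=O)/C=C1\CCc2cc(F)cc(F)c21` carries the same change on the core of compound 1: methyl in place of cyclopropyl on an amide-type nitrogen, at the same place. Going by the values given here, the step for compound 4 is expected to be a number 40 percentage points lower from compound 1 to compound 4 (beyond the scatter), resting on the one earlier step of a number 34 percentage points lower from compound 3 to compound 2 (beyond the scatter) as the only guide, with one core only. In this assay compound 4 is therefore expected to give about 60%, most likely between 35% and 90%.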

Compound 4, a percentage reported as inhibition, in the whole organism at one dose (the size of the read-out at that dose, not a potency): 33%
Beside the measured number, compound 4's estimate is 27 percentage points above it; the whole stated range lies above it.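

The new step is a number 67 percentage points lower from compound 1 to compound 4 (beyond the scatter), so in this assay methyl in place of cyclopropyl on an amide-type nitrogen lowers the number on both cores shown. For the compounds shown here, the direction of the change carries from one core to the other, but its size does not: the same change on two cores in this assay, a number 34 percentage points lower (beyond the scatter) from compound 3 to compound 2 and a number 67 percentage points lower (beyond the scatter) from compound 1 to compound 4, 33 percentage points apart, beyond the scatter of two such steps With only two cores and one dose, these numbers give no rule for the size of the step on a further core, and they do not show what sets the size apart.

The compounds shown leave open how an ethyl group, an isopropyl group or a cyclobutyl ring on the same nitrogen would compare with cyclopropyl and methyl. Also open, going by these compounds, is the size of the step on a core carrying bromine or a single fluorine.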